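Methyl for fluoro on the para position of the anilide

The source may report more compounds than this note shows. Statements on the series, on what has been measured and on what is new or still open speak of the compounds shown alone.

Compound 2 `COc1ccc2c(=O)c(/C=C/C(=O)Nc3ccc(F)cc3)coc2c1` gives 33900 nM in a functional assay on Huh-7 cells (Homo sapiens) for inhibition, read by MTT assay, with a stated time of 48 h (on this read-out higher numbers stand for weaker inhibition and lower numbers for stronger inhibition), the highest of the two numbers recorded, so the weaker of the pair. Compound 1 `COc1ccc2c(=O)c(/C=C/C(=O)Nc3cccc(C)c3)coc2c1` gives 15500 nM in this assay. Within the data shown here, the only measured step, a 2.2-fold higher number from compound 1 to compound 2 (0.34 log units; beyond the scatter), exchanged 3-methylphenyl for 4-fluorophenyl on the amide-type nitrogen, and it combined a change of group with a change of position. Compound 3 `COc1ccc2c(=O)c(/C=C/C(=O)Nc3ccc(C)cc3)coc2c1` differs from compound 2 by methyl in place of fluoro on an aromatic carbon; the same difference, cut one bond further out, reads 4-fluorophenyl to 4-methylphenyl. The step from compound 1 to compound 2 bears on this only in part, since the methyl of compound 1 sits elsewhere on the ring. Compound 3 is therefore expected to give a lower number than compound 2, by a step of roughly a 1.9-fold lower number from compound 2 to compound 3 (0.27 log units; within the scatter), and its estimated value is 18000 nM, with a range from 7000 nM to 45000 nM.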

Compound 3, half-maximal inhibitory concentration: > 100000 nM
Compound 3: no number, only a limit; the forecaster's own chance of this, stated with the estimate: 5%; middle value at least 5.5-fold (0.74 log units) from the limit.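

The reading for compound 3 in this assay is a limit of the assay and not a number: the limit of > 100000 nM in this assay, at which 1 of the 3 values shown sits.

Even so, the step can be read in one direction: methyl in place of fluoro on this aromatic carbon, para to a large group, weakens inhibition, with an at least 2.9-fold higher number from compound 2 to compound 3 (0.46 log units; beyond the scatter). The earlier pair had mixed a change of group with a change of position, whereas this step isolates the group, and an at least 6.4-fold higher number from compound 1 to compound 3 (0.80 log units; beyond the scatter) isolates the position of the methyl, with 4-methylphenyl in place of 3-methylphenyl, so the place of that one methyl counts for much in this series.

From the compounds shown here alone, what stays open is how an amine, a methoxy group or a carboxylic acid in place of the fluoro would read on this carbon. Going by these compounds, it is also open whether any of these would give a lower number than compound 2.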